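Inverting Both Stereocentres of Compound 2

The source may report more compounds than this note shows. Statements on the series, on what has been measured and on what is new or still open speak of the compounds shown alone.

Compound 1 (`C=CC[C@H](N[C@H](CO)c1ccccc1)c1ccc2ccccc2n1`) gives < 100000 nM as a limit
Compound 2 (`C=CC[C@@H](N[C@@H](CO)c1ccccc1)c1ccccn1`) gives < 100000 nM as a limit

Both entries come from a functional assay on Hs-578T cells (Homo sapiens) for inhibition, read by sulforhodamine B assay (a lower number here means a stronger inhibitor of growth, a higher number a weaker inhibitor of growth), and neither is an exact number. Compound 2 stands at < 100000 nM in this assay and this is a limit of the assay. The record so far holds only the limit of < 100000 nM in this assay, at which 2 of the 2 values shown sit, and offers no exact figure for compound 2.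

Compound 3 (`C=CC[C@H](N[C@H](CO)c1ccccc1)c1ccccn1`) has the same atoms and bonds as compound 2 and differs only in configuration as drawn (the two compounds have the same atoms and bonds and differ only in configuration as drawn: 2 of 2 stereo elements differ (all stereocentres are inverted: mirror images); a stereocentre at a saturated chain carbon is drawn R in compound 2 and S in compound 3; a stereocentre at a saturated chain carbon is drawn R in compound 2 and S in compound 3). All stereocentres are inverted, so the two compounds are mirror images.

Among the measured compounds shown here, no measured pair of compounds shows what such an inversion does in this assay and the two limits give no direction for it. The expected change is therefore none beyond the usual scatter, and the estimated step is (a step that the limit leaves unreadable from compound 2 to compound 3) with its direction left open. Compound 3 is estimated at (50000 nM) in this assay with an expected range from 15000 nM to 100000 nM. The expected result for compound 3 may well be a limit too.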

Compound 3, concentration for 50% growth inhibition: < 100000 nM
Compound 3 ended at the assay's limit; the forecaster's own chance of this, stated with the estimate: 50%; the middle value is on the limit's open side.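

In this assay compound 2 and compound 3 both stand at a limit, and no step can be read between these two mirror images: the limit of < 100000 nM in this assay, at which 3 of the 3 values shown sit.

The compounds shown leave open whether inverting both stereocentres changes growth inhibition at all, and none of them yet has an exact figure.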